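The compounds below may be only part of what the source reports. "The series", "measured", "known", "first", "only" and "open" are said of these compounds alone.

Working notes on the series. Compound 3 `O=C(CCCCCCc1nc(-c2ccc(F)cc2)no1)C(F)(F)F` carries the trifluoromethyl ketone end; in an assay on isolated protein for inhibition of histone deacetylase 8 (Homo sapiens), read by fluorescence, with a stated time of 10 min (a higher number here means a weaker inhibitor, a lower number a stronger inhibitor), compound 3 gives 7650 nM. Compound 2 `O=C(CCCCCCc1nc(-c2ccc(C(F)(F)F)cc2)no1)C(F)(F)F` differs from it only at the aromatic carbon; in this assay compound 2 gives 1030 nM. The step of a 7.4-fold higher number from compound 2 to compound 3 (0.87 log units; beyond the scatter) is the only measured step among the numbers shown, and compound 3 therefore stands at the highest of the two numbers, with compound 2 as its nearest neighbour. Compound 1 `Nc1ccccc1NC(=O)CCCCCCc1nc(-c2ccc([N+](=O)[O-])cc2)no1` pairs the nitro-bearing aryl with a different end group; in this assay compound 1 reaches only a limit, > 10000 nM, and so gives no number to compare (the limit of > 10000 nM in this assay, at which 1 of the 3 values shown sits).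

Compound 4 `O=C(CCCCCCc1nc(-c2ccc([N+](=O)[O-])cc2)no1)C(F)(F)F` has not been measured. It differs from compound 3 by nitro in place of fluoro on an aromatic carbon. For the measured compounds named here, the one step that bears on this position, a 7.4-fold higher number from compound 2 to compound 3 (0.87 log units; beyond the scatter), shows that a change at the aromatic carbon can move this assay by a modest amount beyond the scatter; compound 1 shows only that a nitro-bearing aryl with another end group sits at the limit. On that basis the step from compound 3 to compound 4 is expected to be downward, a 2.6-fold lower number from compound 3 to compound 4 (0.41 log units; beyond the scatter). For compound 4 the estimate in this assay is 3000 nM, with a range from 800 nM to 12000 nM.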

Compound 4, half-maximal inhibitory concentration: 3170 nM
Estimate against measurement, compound 4: 1.1-fold (0.02 log units) below; measured number inside the range.
By their numbers in this assay, from the lowest: compound 2; then compound 4; then compound 3. At a limit, above all of these: compound 1.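

At the aromatic carbon para to a large group, with the trifluoromethyl ketone end held constant, nitro in place of fluoro gives a 2.4-fold lower number from compound 3 to compound 4 (0.38 log units; beyond the scatter) in this assay and nitro in place of trifluoromethyl gives a 3.1-fold higher number from compound 2 to compound 4 (0.49 log units; beyond the scatter) so that the three substituents run trifluoromethyl, nitro, fluoro from the lowest number to the highest. For the compounds shown here, compound 4 thus places a third substituent between compound 2 and compound 3, with each of its steps to them beyond the scatter, where the earlier numbers gave only a single step at this position. Trifluoromethyl in place of (2-aminophenyl)amino on a carbonyl carbon, with the nitro-bearing aryl unchanged, gives an at least 3.1-fold lower number from compound 1 to compound 4 (0.49 log units; beyond the scatter) and this first reading of the end group is only a bound, compound 1 being at a limit: the limit of > 10000 nM in this assay, at which 1 of the 4 values shown sits.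

Open, going by these compounds, are where an amine, a methoxy group or a nitrile at this aromatic carbon would fall against these three substituents, and whether a longer chain keeps the same order. With the (2-aminophenyl)amino end only the nitro-bearing compound 1 is shown, so the full size of the end-group step and the order of the substituents with that end cannot be read.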